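The source may report more compounds than this note shows. Statements on the series, on what has been measured and on what is new or still open speak of the compounds shown alone.

Of the compounds shown here, three have so far been tested in a functional assay on HCC827 cells (Homo sapiens) for inhibition, read by MTT assay, with a stated time of 48 h, tested at 10 uM; on this read-out lower numbers stand for less inhibition and higher numbers for more inhibition at the one concentration tested (going by the name of the read-out). Compound 1 `COc1cc(NC(=O)Nc2cc(Nc3ccc(C(C)(C)C)cc3)ncn2)cc(OC)c1` gives 32.7%, the lowest of the three. For the measured compounds named here, compound 2 `Cc1ccc(Nc2cc(NC(=O)Nc3c(Cl)cccc3Cl)ncn2)cc1F` gives 85.3% and compound 3 `Cc1ccc(Nc2cc(NC(=O)Nc3c(Cl)cccc3Cl)ncn2)cc1C` gives 84.3%; the single step between them, a number 1 percentage points lower from compound 2 to compound 3 (within the scatter), is within the scatter. The unmeasured compound 4 `COc1cc(NC(=O)Nc2cc(Nc3ccc(F)c(Cl)c3)ncn2)cc(OC)c1` differs from compound 1 by 3-chloro-4-fluorophenyl in place of 4-(tert-butyl)phenyl on a nitrogen on an aromatic ring. Going by the values given here, no measured step exchanges one aryl group for another on that nitrogen, so there is no direct precedent. Compounds 2 and 3, which carry halogen or methyl groups on the aryl attached to that nitrogen, score far higher than compound 1, yet they also differ elsewhere, so the hint is loose. The expected step is a number 22.3 percentage points higher from compound 1 to compound 4 (beyond the scatter). Compound 4 is therefore estimated at 55%, within a range from 30% to 80%.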

Compound 4, a percentage reported as inhibition, at one concentration (the size of the read-out at that concentration, not a potency): 53.1%
Beside the measured number, compound 4's estimate is 1.9 percentage points above it; the measured number falls inside the stated range.
By their numbers in this assay, from the lowest: compound 1; then compound 4; then compounds 3 and 2 (each within the scatter of the next).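

In this assay, 3-chloro-4-fluorophenyl in place of 4-(tert-butyl)phenyl gives a number 20.4 percentage points higher from compound 1 to compound 4 (beyond the scatter) with the rest of the molecule unchanged. For the compounds shown here, this is the first direct evidence that the aryl group on this nitrogen affects the read-out on this core. No measurement shown explains the rise.

A single exchange cannot show whether the chlorine, the fluorine or the removal of tert-butyl matters most. Going by these compounds, how an unsubstituted phenyl, or an aryl group carrying an amine or a carboxylic acid, would behave at this position remains open.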